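Pyrimidin-4-yl gives way to 5-methyl-1,3,4-oxadiazol-2-yl

The source may report more compounds than this note shows. Statements on the series, on what has been measured and on what is new or still open speak of the compounds shown alone.

- Compound 1 `O=C(C1CCN(c2ncccn2)CC1)N1N=CC[C@H]1c1ccccc1`: > 3.11 h (a limit, not a number)
- Compound 2 `O=C(C1CCN(c2ccncn2)CC1)N1N=CC[C@H]1c1ccccc1`: 3.3 h

For the measured compounds named here, in an ADME assay on cells (Hepatocyte, Homo sapiens) for metabolic stability (on this read-out higher numbers stand for a longer-lived compound and lower numbers for a shorter-lived compound), compound 2 gives 3.3 h, the only true number so far. The value of compound 1 is a limit. Going by the values given here, the one measured change, pyrimidin-4-yl in place of pyrimidin-2-yl, is a step that the limit leaves unreadable from compound 1 to compound 2, so it offers no size to carry forward. Compound 3 `Cc1nnc(N2CCC(C(=O)N3N=CC[C@H]3c3ccccc3)CC2)o1` differs from compound 2 by a larger swap: 5-methyl-1,3,4-oxadiazol-2-yl in place of pyrimidin-4-yl on an amine nitrogen in a ring. With no readable step as a guide, no direction can be expected, and the estimate starts from compound 2 at 3.3 h. The expected change is a 1.1-fold lower number from compound 2 to compound 3 (0.04 log units; within the scatter), no step beyond the scatter. Compound 3 is estimated at 3 h, within 1.5 h to 6.5 h.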

Compound 3, half-life: 3.3 h
The estimate for compound 3 lay 1.1-fold (0.04 log units) below the measured number; low and high end bracket the measured number.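

In this assay, 5-methyl-1,3,4-oxadiazol-2-yl in place of pyrimidin-4-yl on an amine nitrogen in a ring gives no change at the digits printed from compound 2 to compound 3 (within the scatter). For the compounds shown here, this is the first readable step at this position, and it shows that a five-membered aromatic ring can stand in for a six-membered one with no change beyond the scatter. The steps from compound 1 cannot be read, as its value is a limit: the limit of > 3.11 h in this assay, at which 1 of the 3 values shown sits.

As far as these compounds go, how compound 1 truly ranks therefore stays open. So does whether a non-aromatic group on this nitrogen, such as acetyl, would give a similar half-life.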